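The compounds below may be only part of what the source reports. "The series", "measured", "known", "first", "only" and "open" are said of these compounds alone.

Measured so far in a functional assay on PC-3 cells (Homo sapiens) for antiproliferative activity, read by MTT assay, tested at 1 uM; a lower number here means a weaker effect, a higher number a stronger effect of the compound at the concentration tested:

compound 1 `COc1cc(C2=NN(C(C)=O)C(c3cccc(OC)c3OC)O2)cc(OC)c1OC` — 35%
compound 2 `COc1cc(C(=O)N/N=C/c2cccc(C(F)(F)F)c2)cc(OC)c1OC` — 51%
compound 3 `COc1cccc(/C=N/NC(=O)c2cc(OC)c(OC)c(OC)c2)c1OC` — 53.2%

Compound 1 stands lowest of the three numbers in this assay. Compound 2 lies nearest, higher by an amount beyond the scatter, and compound 3 lies furthest, also beyond the scatter. Within the data shown here, no pair of measured compounds differs in one place only, so no single-change step is known.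

Compound 4 `COc1cc(C2=NN(C(C)=O)C(c3ccc(Cl)c(Cl)c3)O2)cc(OC)c1OC` is not yet measured. It differs from compound 1 by 3,4-dichlorophenyl in place of 2,3-dimethoxyphenyl on a saturated ring carbon. Nothing measured shows this exchange on the shared core, so the direction is open; the expected step of a number 5 percentage points higher from compound 1 to compound 4 (within the scatter) is small, likely within the scatter. Compound 4 is estimated at 40%, with a range from 20% to 62%.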

Compound 4, a percentage reported as inhibition, at one concentration (the size of the read-out at that concentration, not a potency): 28.1%
Estimate against measurement, compound 4: 11.9 percentage points above; the measured number falls inside the stated range.
By their numbers in this assay, from the lowest: compounds 4 and 1 (each within the scatter of the next); then compounds 2 and 3 (each within the scatter of the next).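

Among these compounds, on a saturated ring carbon of the shared core, 3,4-dichlorophenyl in place of 2,3-dimethoxyphenyl gives, in this assay, a number 6.9 percentage points lower from compound 1 to compound 4 (within the scatter) and provides the first single-place step. At this position, the two methoxy groups are therefore not shown to be required for the read-out, and two chlorines serve equally within the scatter. No measurement on hand explains this result. Still open, on these data alone, is whether an amine, a carboxylic acid or a longer chain at this ring carbon would shift the read-out. As far as these compounds go, the effect of replacing the acetyl group on the shared core also remains open.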